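Swapping the aryl amine group on the shared core

This account rests on a few compounds, and the source may have more. Where it says the series, first, only, none or still open, it means among the compounds named here.

Compound 2 `Nc1ccccc1NC(=O)c1ccc(COCNc2nc(Nc3ccc(-c4ccccc4)cc3)c3ncn(C4CCCC4)c3n2)cc1` and compound 1 `Nc1ccccc1NC(=O)/C=C/c1ccc(Cn2cnc3c(Nc4ccccc4)nc(Cl)nc32)cc1` were both tested in a functional assay on HCT-116 cells (Homo sapiens) for antiproliferative activity, read by CCK-8 assay, with a stated time of 72 h, tested at 2 uM; on this read-out lower numbers stand for a weaker effect and higher numbers for a stronger effect at the one concentration tested. Compound 2 gives 9.41%, the higher of the two numbers, while compound 1 gives 7.75%; the gap between them lies within the usual scatter, so neither can be called the stronger. Compound 3 `Nc1ccccc1NC(=O)c1ccc(COCNc2nc(Nc3cccc(Cl)c3)c3ncn(C4CCCC4)c3n2)cc1` differs from compound 2 by 3-chlorophenyl in place of 4-phenylphenyl on a nitrogen on an aromatic ring. Among the compounds with values here, with no measured step to lean on and both known values low, a change no larger than the scatter is expected, so the step of a number 0.4 percentage points lower from compound 2 to compound 3 (within the scatter) is estimated to be small in either direction. Compound 3 is expected to give 9%, within 0% to 25%.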

Compound 3, a percentage reported as inhibition, at one concentration (the size of the read-out at that concentration, not a potency): 29.2%
Estimate against measurement, compound 3: 20.2 percentage points below; measured number above the stated range.
By their numbers in this assay, from the lowest: compounds 1 and 2 (each within the scatter of the next); then compound 3.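

In this assay, 3-chlorophenyl in place of 4-phenylphenyl gives a number 19.8 percentage points higher from compound 2 to compound 3 (beyond the scatter) on the shared core, the first change shown to move the number by more than the scatter. So what sits on this nitrogen on an aromatic ring does matter here, which the two earlier compounds could not show. No measurement at hand explains the rise.

From the compounds shown here alone, it remains open whether the gain goes with the chlorine or with the loss of the second ring. Fluorine or a methoxy group in place of the chlorine could help separate the two.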